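The source may report more compounds than this note shows. Statements on the series, on what has been measured and on what is new or still open speak of the compounds shown alone.

In a functional assay (aorta) with Rattus norvegicus as the target (on this read-out lower numbers stand for stronger inhibition and higher numbers for weaker inhibition), compound 1 (`CCN(CC)CCCOc1ccc(S(=O)(=O)c2c(C)cn3ccccc23)cc1`) gives 3390 nM while compound 2 (`COc1ccc(CN(C)CCCCOc2ccc(S(=O)(=O)c3c(C(C)C)cn4ccccc34)cc2)cc1OC`) gives 14.6 nM and compound 3 (`CC(C)c1cn2ccccc2c1S(=O)(=O)c1ccc(OCCCNCc2ccccc2)cc1`) gives 22.8 nM as the middle number of the three. Compound 3 is level with compound 2 within the usual scatter and lies far from compound 1. Compound 4 (`CC(C)c1cn2ccccc2c1S(=O)(=O)c1ccc(OCCCN2CCN(c3ccccc3)CC2)cc1`) carries 4-phenylpiperazin-1-yl in place of benzylamino on a saturated chain carbon, three bonds along the chain from an oxygen on an aromatic ring. For the measured compounds named here, no measured pair shows this change alone. Unlike compound 3, compound 2 carries a different amine group and at 14.6 nM stays within the scatter of it, so no step beyond the scatter is expected in this assay here. A small change toward weaker inhibition is expected (a 1.8-fold higher number from compound 3 to compound 4 (0.24 log units; within the scatter)). Compound 4 is expected at 40 nM (estimated range 10 nM to 200 nM).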

Compound 4, half-maximal inhibitory concentration: 205 nM
Beside the measured number, compound 4's estimate is 5.1-fold (0.71 log units) below it; the whole stated range lies below it.
By their numbers in this assay, from the lowest: compounds 2 and 3 (each within the scatter of the next); then compound 4; then compound 1.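

In this assay, for the compounds shown here, swapping the amine on this chain can clearly matter: 4-phenylpiperazin-1-yl in place of benzylamino gives a 9.0-fold higher number from compound 3 to compound 4 (0.95 log units; beyond the scatter) and is the first single change in this set to be read beyond the scatter. The entering group is larger and has no hydrogen-bond donor, whereas benzylamino has one, but these counts do not identify which difference matters. Nothing measured here explains the step. Still open, from the compounds shown here alone, is which part of the new group counts: a plain piperazine or a morpholine on the same saturated chain carbon would separate the ring from the phenyl.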